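Acyl change on the ring nitrogen of the core

The source may hold more compounds than are shown below. What is called first, only, known or untested is meant among the compounds shown, and "the series" means these compounds.

Measured compounds in a functional assay on MDA-MB-231 cells (Homo sapiens) for cytotoxicity, read by sulforhodamine B assay, with a stated time of 72 h; a higher number here means a weaker inhibitor of growth, a lower number a stronger inhibitor of growth:
compound 1 `O=C(Nc1ccccc1C(F)(F)F)C1CCc2ccccc2N1C(=O)c1ccccc1`: 5290 nM
compound 2 `O=C(Nc1cc(C(F)(F)F)cc(C(F)(F)F)c1)C1CCc2ccccc2N1C(=O)c1ccccc1Cl`: 5250 nM
compound 3 `O=C(Nc1ccccc1O)C1CCc2ccccc2N1C(=O)c1ccccc1`: 4210 nM

Within the data shown here, compound 1 has the highest of the three numbers, but the spread is narrow: the values of compound 1 and compound 2 lie within the scatter of each other, and the one step in the set, a 1.3-fold lower number from compound 1 to compound 3 (0.10 log units; within the scatter), is within the scatter too, so none of the three can be set apart from the others. That step, measured in one place, concerns the anilide ring and leaves the acyl group on the ring nitrogen untouched.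

Compound 4 `CCCC(=O)N1c2ccccc2CCC1C(=O)Nc1ccccc1C(F)(F)F` differs from compound 1 at that acyl group: propyl in place of phenyl on a carbonyl carbon. Among the measured compounds shown here, no measured pair alters this position alone; compound 2 carries a chloro on the benzoyl ring but also a different anilide, so its value against compound 1 only shows that the two numbers lie within the scatter. Nothing in the set therefore speaks for a step beyond the scatter in this assay in either direction, and the estimate for compound 4 rests on the flat picture of the three measured values. The expected step is a 1.1-fold higher number from compound 1 to compound 4 (0.05 log units; within the scatter). For compound 4 the estimated value in this assay is 6000 nM, with a range from 2500 nM to 15000 nM.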

Compound 4, concentration for 50% growth inhibition: > 70000 nM
Compound 4 ended at the assay's limit (the forecaster's own chance of this, stated with the estimate: 5%); middle value at least 11-fold (1.06 log units) away from the limit.
By their numbers in this assay, from the lowest: compounds 3, 2 and 1 (each within the scatter of the next). At a limit, above all of these: compound 4.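

Among these compounds, the acyl group on the ring nitrogen is the first position where a single change moves the number beyond the scatter: an at least 13-fold higher number from compound 1 to compound 4 (1.12 log units; beyond the scatter). The anilide change from compound 1 to compound 3 gave no such separation, so the flat picture of the earlier values does not extend to this position, and the benzoyl to propylcarbonyl change matters far more in this assay than that set suggested. For compound 4 the reading is a limit of the assay and not a number, so the step gives only a lower bound on the size of the change: the limit of > 70000 nM in this assay, at which 1 of the 4 values shown sits.

Compounds 1, 2 and 3 all carry an aromatic ring on this carbonyl, and compound 4, the only one without it, is the only one at the limit, but a single replacement cannot show whether the aromatic ring itself or the larger group as a whole is what counts. A cyclohexyl group on the same carbonyl would separate these two readings, and a longer chain, such as hexyl, would show whether chain length alone changes the result.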